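The source may hold more compounds than are shown below. What is called first, only, known or untested is meant among the compounds shown, and "the series" means these compounds.

Compound 1 `CCOC(=O)c1cc([Se]c2ccccc2)c2cc(Br)ccc2n1`: 20800 nM
Compound 2 `CCOC(=O)c1cc([Se]c2ccc(F)cc2)c2cc(OC)ccc2n1`: 134000 nM
Compound 3 `CCOC(=O)c1cc([Se]c2ccc3cc(OC)ccc3c2)c2cc(OC)ccc2n1`: 31300 nM

These three numbers come from a functional assay on Jurkat cells (Homo sapiens) for cytotoxicity, read by MTT assay, with a stated time of 24 h; on this read-out lower numbers stand for an effect already at smaller amounts and higher numbers for an effect only at larger amounts of compound. Compound 1 stands at the low end of the set, together with compound 3, and the two values lie within the usual scatter of each other. Compound 2 has a clearly higher number than compound 1, and that gap goes beyond the scatter.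

The next compound to be tested is compound 4 `CCOC(=O)c1cc([Se]c2ccccc2)c2cc(Cl)ccc2n1`. It keeps everything in compound 1 except one group: chloro in place of bromo on an aromatic carbon.

Within the data shown here, no two measured compounds differ in only one place, so the data contain no direct measure of what a single swap does. Compound 2 and compound 3 differ from compound 1 in more than one place and offer only a loose guide. The estimate therefore rests on the closest measured relative, compound 1 at 20800 nM. No change beyond the scatter is expected, and no firm direction can be given.

The expected change, a 1.2-fold higher number from compound 1 to compound 4 (0.06 log units; within the scatter), is small. In this assay, the estimated value for compound 4 is 24000 nM, with an expected range of 11000 nM to 55000 nM.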

Compound 4, half-maximal effective concentration: 53000 nM
For compound 4 the middle estimate is 2.2-fold (0.34 log units) below the measured one, and the stated range covers the measured number.
By their numbers in this assay, from the lowest: compounds 1, 3 and 4 (each within the scatter of the next, the first and the last beyond it); then compound 2.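

Among these compounds, this is the first pair in the set that differs in one place only, and so the first direct reading of a single swap: in this assay putting chloro in place of bromo on this aromatic carbon gives a 2.5-fold higher number from compound 1 to compound 4 (0.41 log units; beyond the scatter) and thus shows that the position responds to the choice of halogen. The step is modest but lies beyond the usual scatter, so even an exchange that leaves the count of heavy atoms, rings, hydrogen-bond donors and acceptors unchanged can move the number here, and of these two halogens bromo gives the lower number. Nothing available explains why the two halogens differ in this way.

The compounds shown leave open how other groups would fare at this position, such as iodo, a nitrile or an amine, or the bare ring carbon with only hydrogen on it. Among the compounds shown here, they also leave open whether the same swap would give a similar step when the phenyl group on selenium is replaced, since this single pair carries only that one group.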